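The source may report more compounds than this note shows. Statements on the series, on what has been measured and on what is new or still open speak of the compounds shown alone.

Within the data shown here, compound 2 `COC(=O)N1CCN(C(=O)c2nc(Nc3cc(C4CC4)[nH]n3)c3cc(Cl)ccc3n2)C[C@H]1C` stands highest of the two numbers so far in an assay for inhibition of serine/threonine-protein kinase PAK 4 (Homo sapiens), read by FRET and Z'-LYTE, with a stated time of 60 min, tested at 50 uM, in the presence of a further agent that is not named here (on this read-out higher numbers stand for a stronger effect at the one concentration tested and lower numbers for a weaker effect), giving 98.5%. Compound 1 `C[C@@H]1CN(C(=O)c2nc(Nc3cc(C4CC4)[nH]n3)c3cc(Cl)ccc3n2)CCN1C(=O)OC(C)(C)C` gives 36.4% in this assay. Among the measured compounds shown here, the one measured step, a number 62.1 percentage points higher from compound 1 to compound 2 (beyond the scatter), is the only change at the oxygen next to a carbonyl group and so the only one that bears on compound 3 `CC(OC(=O)C(C)C)OC(=O)N1CCN(C(=O)c2nc(Nc3cc(C4CC4)[nH]n3)c3cc(Cl)ccc3n2)C[C@H]1C`, which differs from compound 2 as follows: 1-((isopropylcarbonyl)oxy)ethyl in place of methyl on an oxygen next to a carbonyl group. That step shows that swapping the group on this oxygen can move the read-out strongly, and in the one case seen, leaving methyl for tert-butyl went with the much lower number of compound 1. Going from methyl to 1-((isopropylcarbonyl)oxy)ethyl is likewise a move away from methyl, so a drop beyond the scatter is expected, of about a number 33.5 percentage points lower from compound 2 to compound 3 (beyond the scatter) in this assay, though its size is uncertain. Compound 3 is therefore estimated at 65%, within 25% to 99%.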

Compound 3, a percentage reported as inhibition, at one concentration (the size of the read-out at that concentration, not a potency): 71.7%
The estimate for compound 3 lay 6.7 percentage points below the measured number, and the stated range covers the measured number.
By their numbers in this assay, from the lowest: compound 1; then compound 3; then compound 2.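

In this assay, 1-((isopropylcarbonyl)oxy)ethyl in place of methyl on an oxygen next to a carbonyl group gives a number 26.8 percentage points lower from compound 2 to compound 3 (beyond the scatter) and so costs less than tert-butyl did, while in place of tert-butyl it gives a number 35.3 percentage points higher from compound 1 to compound 3 (beyond the scatter) and so recovers part of that loss. Across these three compounds, the number does not simply fall as the group on this oxygen grows: the entering group, with 8 heavy atoms against 1 for methyl, still stands above the tert-butyl compound. Nothing at hand accounts for these differences.

On these data alone, whether ethyl, a longer chain or a group carrying an amine on this oxygen would stand nearer compound 2 or compound 1 remains open. As far as these compounds go, these numbers show a stronger or weaker effect at the one concentration tested only, so how the three compounds would compare at other concentrations also remains open.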